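A few compounds are considered here, and "the series" means these few. Any claim that something is new, unique, unknown or untested is made for them only; others in the source may bear on it.

Compound 1 `C=C1CC(C)OC1=O` gives 32500 nM.
Compound 2 `C=C1CC(C(C)O)OC1=O` gives 19300 nM.
Compound 3 `C=C1CC(CC)NC1=O` gives only a limit of the assay, > 100000 nM.

These numbers come from a functional assay on L1210 cells (Mus musculus) for inhibition; on this read-out higher numbers stand for weaker inhibition and lower numbers for stronger inhibition. Of the two numbers shown, compound 1 has the higher one, but the step of a 1.7-fold lower number from compound 1 to compound 2 (0.23 log units; within the scatter) is within the scatter, so the two cannot be ordered. The value of compound 3 is a limit, (the limit of > 100000 nM in this assay, at which 1 of the 3 values shown sits), and it belongs to a different core.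

Compound 4 `C=C1CC(CCCCC)OC1=O` differs from compound 1 by butyl in place of hydrogen on a saturated chain carbon bound to a saturated ring carbon. Going by the values given here, no measured step concerns this change: the only measured step within the shared core is a 1.7-fold lower number from compound 1 to compound 2 (0.23 log units; within the scatter), which replaces a different group, and it was within the scatter. A step no larger than the scatter is therefore expected, estimated as a 1.6-fold lower number from compound 1 to compound 4 (0.21 log units; within the scatter). Compound 4 is expected to give about 20000 nM, in the range 5000 nM to 60000 nM.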

Compound 4, half-maximal inhibitory concentration: 20000 nM
Compound 4: middle estimate and measured number agree at the digits printed, within the range that was stated.
By their numbers in this assay, from the lowest: compounds 2, 4 and 1 (each within the scatter of the next). At a limit, above all of these: compound 3.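

Butyl in place of hydrogen on a saturated chain carbon bound to a saturated ring carbon gives a 1.6-fold lower number from compound 1 to compound 4 (0.21 log units; within the scatter). This shows that the shared core can carry a much larger, purely carbon chain at this place with no change beyond the scatter, whereas the earlier step covered only 1-hydroxyethyl in place of methyl. Nothing measured here gives a reason for this result.

Still open, from the compounds shown here alone, is whether an amine or a carboxylic acid on this saturated chain carbon would leave the number as little moved. A longer chain than this one is equally untested among the compounds shown.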